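The source may hold more compounds than are shown below. What is called first, only, known or untested is meant among the compounds shown, and "the series" means these compounds.

a functional assay (Nicotiana tabacum) (a higher number here means a weaker inhibitor, a lower number a stronger inhibitor), gives these values so far:

- Compound 1 `CCCNc1nc(SC)nc2ncccc12` gives 270 nM
- Compound 2 `CCCCCNc1nc(SC)nc2ncccc12` gives 650 nM
- Compound 3 `C=CCNc1nc(SC)nc2ncccc12` gives 400 nM

Compound 3 stands close to both of the others, with a 1.5-fold higher number from compound 1 to compound 3 (0.17 log units; within the scatter) and a 1.6-fold lower number from compound 2 to compound 3 (0.21 log units; within the scatter) on the numbers shown. Compound 4 `CSc1nc(Nc2ccccc2)c2cccnc2n1` differs from compound 3 in one place (phenyl in place of allyl on a nitrogen on an aromatic ring). Going by the values given here, the only measured step beyond the scatter is a 2.4-fold higher number from compound 1 to compound 2 (0.38 log units; beyond the scatter) where ethyl replaces hydrogen on the chain, so a larger group there went with a modest rise. Among the compounds with values here, no measured compound carries a ring on that nitrogen, so these steps are only a loose guide. In this assay a modest rise is expected, with an estimated 2.3-fold higher number from compound 3 to compound 4 (0.35 log units; beyond the scatter) as the working figure. The estimate for compound 4 is 900 nM (expected range 250 nM to 3500 nM).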

Compound 4, half-maximal inhibitory concentration: 15900 nM
The estimate for compound 4 lay 18-fold (1.25 log units) below the measured number; measured number outside the range, above it.
By their numbers in this assay, from the lowest: compounds 1, 3 and 2 (each within the scatter of the next, the first and the last beyond it); then compound 4.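

In this assay, a phenyl on this nitrogen weakens inhibition far more than any change among the open chains did, whichever chain it replaces (a 40-fold higher number from compound 3 to compound 4 (1.60 log units; beyond the scatter); a 24-fold higher number from compound 2 to compound 4 (1.39 log units; beyond the scatter); a 59-fold higher number from compound 1 to compound 4 (1.77 log units; beyond the scatter)). So this position accepts propyl, allyl and pentyl with only small shifts, while phenyl brings a large loss. Nothing available explains this loss. From the compounds shown here alone, it remains open whether the loss comes from having a ring at all or from the aromatic ring sitting directly on the nitrogen. A benzyl or cyclohexyl group there could separate these two readings.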